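Cytotoxicity in the aryloxy-anilino series: core swap and amine tail

This account rests on a few compounds, and the source may have more. Where it says the series, first, only, none or still open, it means among the compounds named here.

Compound 2 `C=CCNc1cc(Oc2c(C)cc(/C=C/C#N)cc2C)nc(Nc2ccc(C#N)cc2)n1` and compound 1 `COCCNc1cc(Oc2c(C)cc(/C=C/C#N)cc2C)nc(Nc2ccc(C#N)cc2)n1` share one core; compound 3 `C=CCNc1cc(Oc2c(C)cc(/C=C/C#N)cc2C)cc(Nc2ccc(C#N)cc2)n1` and compound 4 `COCCNc1cc(Oc2c(C)cc(/C=C/C#N)cc2C)cc(Nc2ccc(C#N)cc2)n1` share another. The difference between the two cores is not broken down here. In an ADME assay on MT4 cells (Homo sapiens) for cytotoxicity, read by MTT assay, with a stated time of 5 days (a higher number here means that more compound is tolerated, a lower number that less compound is tolerated), compound 2 gives 3050 nM. Compound 1 gives 3190 nM in this assay. The two differ only in the amine tail, (methoxymethyl in place of vinyl on a saturated chain carbon bound to a nitrogen on an aromatic ring), and the step of a 1.0-fold higher number from compound 2 to compound 1 (0.02 log units; within the scatter) shows that, on this core, the tail change leaves tolerance unchanged.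

Compound 3 carries the allylamino tail on the second core and gives 82100 nM in this assay, the highest number of the three measured compounds; its nearest neighbour, compound 1, sits far lower, and compound 2 lower still, both gaps well beyond the scatter. Against compound 2 the two structures differ in more than one place, so what separates them is not attributed to a single group.

Compound 4 is compound 3 with the same change, (methoxymethyl in place of vinyl on a saturated chain carbon bound to a nitrogen on an aromatic ring), the place being the same in both pairs. Because the earlier step of a 1.0-fold higher number from compound 2 to compound 1 (0.02 log units; within the scatter) was flat, the step from compound 3 to compound 4 is expected to be flat as well, a 1.0-fold lower number from compound 3 to compound 4 (0.01 log units; within the scatter), resting on one measured pair only. Compound 4 is therefore estimated at 80000 nM in this assay, with a range of 40000 nM to 160000 nM expected.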

Compound 4, half-maximal cytotoxic concentration: 58200 nM
Compound 4: middle estimate off by 1.4-fold (0.14 log units), on the high side, within the range that was stated.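

In this assay, replacing the allylamino tail with the (2-methoxyethyl)amino tail on the core of compound 3 gives a 1.4-fold lower number from compound 3 to compound 4 (0.15 log units; within the scatter), so tolerance stays within the scatter on this core as well. Set beside the same change on the core of compound 2, the two steps do not differ by more than the scatter allows: the same change on two cores in this assay, a 1.0-fold higher number (0.02 log units; within the scatter) from compound 2 to compound 1 and a 1.4-fold lower number (0.15 log units; within the scatter) from compound 3 to compound 4, 1.5-fold (0.17 log units) apart, within the scatter of two such steps. For these two pairs, the change carries from one core to the other without a readable shift in this assay, but this rests on a single change on two cores and shows neither a general rule for the series nor why the tail has so little effect.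

Still open, as far as these compounds go, is whether the same flat result holds for a longer chain such as 3-methoxypropyl, or for a tail ending in an amine or a carboxylic acid. Also open is whether the change behaves the same way on any core other than the two shown, or in any read-out other than this cytotoxicity measure.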